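The source may report more compounds than this note shows. Statements on the series, on what has been measured and on what is new or still open speak of the compounds shown alone.

Three compounds have numbers in an assay on isolated protein for inhibition of protein kinase C theta type (Homo sapiens), read by TR-FRET, with a stated time of 2 h (a lower number here means a stronger inhibitor, a higher number a weaker inhibitor), so far. Compound 1, `N#Cc1cnc(NCc2cnccc2C(F)(F)F)cc1NC[C@H]1C[C@@H](O)C1`, gives 300 nM in this assay, and it stands at the highest of the three numbers. Compound 2, `CC(C)(C)Oc1ncncc1CNc1cc(N[C@H]2CC[C@@H](O)CC2)c(C#N)cn1`, gives 200 nM in this assay, which lies within the scatter of compound 1, so the two cannot be ordered. Compound 3, `CC1(C)C[C@H](Nc2cc(NCc3cnccc3C(F)(F)F)ncc2C#N)CC(C)(C)[C@H]1O`, gives 20 nM in this assay, a number that sits well beyond the scatter from compound 1 and marks the lower end of what has been seen.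

The account now turns to compound 4, `CC1(C)C[C@H](Nc2cc(NCc3cnccc3C(F)(F)F)ncc2C#N)CC[C@H]1O`, which has not yet been measured. It differs from compound 1 in one place: 4-hydroxy-3,3-dimethylcyclohexyl in place of (3-hydroxycyclobutyl)methyl on a nitrogen on an aromatic ring. The group that enters is a six-membered ring bearing a hydroxyl, closer in kind to the ring on compound 3 than to the four-membered ring on compound 1, though it carries fewer methyl groups than the ring of compound 3.

For the measured compounds named here, with no measured step of this exact kind, the expectation rests on the gap between compound 1 and compound 3. The step of a 6.0-fold lower number from compound 1 to compound 4 (0.78 log units; beyond the scatter) is expected to be a drop in the number that falls short of the full gap shown by compound 3 at 20 nM. Compound 4 is estimated at 50 nM, with a range from 15 nM to 150 nM.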

Compound 4, half-maximal inhibitory concentration: 100 nM
Beside the measured number, compound 4's estimate is 2.0-fold (0.30 log units) below it, and the stated range covers the measured number.
By their numbers in this assay, from the lowest: compound 3; then compounds 4, 2 and 1 (each within the scatter of the next, the first and the last beyond it).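

In this assay, putting 4-hydroxy-3,3-dimethylcyclohexyl in place of (3-hydroxycyclobutyl)methyl on this nitrogen gives a 3.0-fold lower number from compound 1 to compound 4 (0.48 log units; beyond the scatter), a modest step that shows this position responds to the change of group, even though the hydrogen-bond donor and acceptor counts stay the same. The ring of compound 4 differs from that of compound 3 only in carrying fewer methyl groups, and the printed values of compound 3 at 20 nM and compound 4 at 100 nM suggest that the methyl pattern on the six-membered ring also matters in this series. Nothing available explains either difference.

The step from compound 1 to compound 4 changes the ring size, the length of the link to the nitrogen and the methyl groups at once, so the share of each remains unresolved. Also open, as far as these compounds go, is how a plain 4-hydroxycyclohexyl ring with no methyl groups, or an amine in place of the hydroxyl on the dimethylcyclohexyl ring, would read in this assay.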